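A few compounds are considered here, and "the series" means these few. Any claim that something is new, unique, unknown or untested is made for them only; others in the source may bear on it.

Measured so far:
- compound 1 `O=C(O)c1ccc(C(=O)C2=C(O)C(=O)N(c3ccc(-c4ccon4)cc3)C2C2CCCCC2)cc1`, which in an ADME assay on the whole organism (Rattus norvegicus) for pharmacokinetics (on this read-out lower numbers stand for slow clearance and higher numbers for fast clearance), gives 1.9 mL/min/kg
- compound 2 `COc1ccc(C(=O)C2=C(O)C(=O)N(c3ccc(-c4ccon4)cc3)C2c2ccccc2OCCO)cc1`, which in this assay gives 67.6 mL/min/kg
- compound 3 `CC(C)(C)C(=O)C1=C(O)C(=O)N(c2ccc(-c3ccon3)cc2)C1c1ccccc1OCCO`, which in this assay gives 2.9 mL/min/kg

Among these three numbers compound 3 stands second highest. Its nearest neighbour is compound 1, whose value lies within the scatter of compound 3, so no order between the two can be read. Among the measured compounds shown here, compound 2 is the far one: the only step between compounds that differ in one place, a 23-fold lower number from compound 2 to compound 3 (1.37 log units; beyond the scatter), is large and well beyond the scatter.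

Compound 4 `CC(C)(C)C(=O)C1=C(O)C(=O)N(c2ccc(-c3cccs3)cc2)C1c1ccccc1OCCO` is the unmeasured member. It differs from compound 3 in one place: thiophen-2-yl in place of 1,2-oxazol-3-yl on an aromatic carbon. The acyl group, the cyclohexyl and the ethylene glycol ether are kept, so the step that was measured, from compound 2 to compound 3, does not touch the part of the molecule that changes here. For the measured compounds named here, no measured pair shows what an exchange of the five-membered heteroaryl ring on the aryl amide does in this assay. The account therefore rests on compound 3 alone, and the step of a 1.4-fold higher number from compound 3 to compound 4 (0.14 log units; within the scatter) is expected to stay within the scatter. For compound 4 a value of 4 mL/min/kg is expected, with a range from 1.5 mL/min/kg to 12 mL/min/kg.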

Compound 4, clearance: 1.3 mL/min/kg
For compound 4 the middle estimate is 3.1-fold (0.49 log units) above the measured one, and the stated range ends above it.
By their numbers in this assay, from the lowest: compounds 4, 1 and 3 (each within the scatter of the next, the first and the last beyond it); then compound 2.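

In this assay, exchanging 1,2-oxazol-3-yl for thiophen-2-yl gives a 2.2-fold lower number from compound 3 to compound 4 (0.35 log units; beyond the scatter), so the group on this aromatic carbon, para to a large group, can also move the read-out beyond the scatter, which the earlier step on the carbonyl carbon could not show. This step is modest, whereas a 23-fold lower number from compound 2 to compound 3 (1.37 log units; beyond the scatter) is large, and it comes at an unchanged count of 5 heavy atoms, with a ring of 1 hetero atom and 1 hydrogen-bond acceptor entering where a ring of 2 hetero atoms and 2 hydrogen-bond acceptors leaves. Nothing at hand explains why the number falls with this exchange.

The compounds shown leave open whether the same exchange also lowers the number when 4-methoxyphenyl stands on the carbonyl carbon in place of tert-butyl, as in compound 2, which gives 67.6 mL/min/kg with 1,2-oxazol-3-yl at this position. They also leave open what a plain phenyl, a pyridine ring or a thiophene carrying a carboxylic acid would do at this position.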